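Amide series: from cyclopentylcarbamoyl to methoxycarbonyl

The compounds below may be only part of what the source reports. "The series", "measured", "known", "first", "only" and "open" are said of these compounds alone.

Measured in a functional assay on PC-3 cells (Homo sapiens) for inhibition, read by sulforhodamine B assay, with a stated time of 72 h; a higher number here means a weaker inhibitor, a lower number a stronger inhibitor:
- compound 1 `Nc1sc(-c2ccc(Cl)cc2)c(-c2ccc(Cl)cc2)c1C(=O)NC1CCCCC1`: 7300 nM
- compound 2 `Nc1sc(-c2ccc(Cl)cc2)c(-c2ccc(Cl)cc2)c1C(=O)NC1CCC1`: 24800 nM
- compound 3 `Nc1sc(-c2ccc(Cl)cc2)c(-c2ccc(Cl)cc2)c1C(=O)NC1CCCC1`: 21200 nM

The cyclopentyl amide shares the weak end of this small set with the cyclobutyl amide, a 1.2-fold lower number from compound 2 to compound 3 (0.07 log units; within the scatter). The cyclohexyl amide stands apart, a 2.9-fold higher number from compound 1 to compound 3 (0.46 log units; beyond the scatter).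

The next compound is compound 4 `COC(=O)c1c(N)sc(-c2ccc(Cl)cc2)c1-c1ccc(Cl)cc1`, with methoxy in place of cyclopentylamino on a carbonyl carbon. Going by the values given here, no measured step replaces the amide itself, so the evidence is indirect. The nearest guides are the changes of ring size on the amide-type nitrogen, a 3.4-fold higher number from compound 1 to compound 2 (0.53 log units; beyond the scatter) and a 2.9-fold higher number from compound 1 to compound 3 (0.46 log units; beyond the scatter), both modest. They give no direction for the loss of the amide, so no clear shift in this assay is expected, though a modest move either way would not surprise. The expected change is a 1.1-fold lower number from compound 3 to compound 4 (0.03 log units; within the scatter). For compound 4 the estimated value is 20000 nM, with an expected range of 7000 nM to 60000 nM.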

Compound 4, half-maximal inhibitory concentration: 2780 nM
Beside the measured number, compound 4's estimate is 7.2-fold (0.86 log units) above it, outside the stated range (below it).
By their numbers in this assay, from the lowest: compound 4; then compound 1; then compounds 3 and 2 (each within the scatter of the next).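

In this assay the amide is not needed at this carbonyl carbon: methoxy in place of cyclopentylamino gives a 7.6-fold lower number from compound 3 to compound 4 (0.88 log units; beyond the scatter) and methoxy in place of cyclobutylamino gives an 8.9-fold lower number from compound 2 to compound 4 (0.95 log units; beyond the scatter) while the ring and the amide hydrogen are lost. The gain also holds against the cyclohexyl amide, with a 2.6-fold lower number from compound 1 to compound 4 (0.42 log units; beyond the scatter) so compound 4 has the lowest number of the four, and no ring on this group is required to reach it. No measured evidence here accounts for the change.

Whether the lower number follows the methoxy group itself or the loss of the amide hydrogen stays open, since the compounds shown include no ethoxy group, carboxylic acid or N-methyl amide at this carbonyl carbon. From the compounds shown here alone, how a longer alkoxy chain would compare with methoxy also remains unknown.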